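Cyclopropane amides: thiazolyl in place of tolyl

This account rests on a few compounds, and the source may have more. Where it says the series, first, only, none or still open, it means among the compounds named here.

Two compounds of this series have been run in a functional assay for agonist activity at G protein-coupled receptor 88 (Homo sapiens), read by HTRF and cAMP accumulation; on this read-out higher numbers stand for an effect only at larger amounts of compound and lower numbers for an effect already at smaller amounts. Compound 1 `CC(C)CCCN(C(=O)[C@@H]1C[C@H]1c1ccccc1)c1ccc(-c2ccccc2)cc1` returns only a limit, > 100 nM, in this assay. Among the compounds with values here, compound 2 `CC[C@H](C)[C@H](N)CN(C(=O)[C@@H]1C[C@H]1c1cccc(C)c1)c1ccc(-c2ccccc2)cc1` gives 1200 nM in this assay, which is the only plain number so far. The other entry, that of compound 1, is a limit (the limit of > 100 nM in this assay, at which 1 of the 2 values shown sits). Compound 2 therefore cannot be ranked against anything yet.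

Compound 3 `CC[C@H](C)[C@H](N)CN(C(=O)[C@@H]1C[C@H]1c1nc(C)c(C)s1)c1ccc(-c2ccccc2)cc1` is the untested member. It differs from compound 2 in one place: 4,5-dimethyl-1,3-thiazol-2-yl in place of 3-methylphenyl on a saturated ring carbon. Within the data shown here, no pair of measured compounds differs in a single place, so no measured step speaks to what such an aryl exchange does here, and the amine-bearing side chain and the biphenyl part are kept.

The expected step is a 1.3-fold higher number from compound 2 to compound 3 (0.10 log units; within the scatter), a change of roughly the scatter of this assay, direction uncertain. Compound 3 is estimated at 1500 nM in this assay, with a range of 400 nM to 6000 nM.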

Compound 3, half-maximal effective concentration: 3600 nM
Beside the measured number, compound 3's estimate is 2.4-fold (0.38 log units) below it; measured number inside the range.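

At the saturated ring carbon of the three-membered ring, the exchange of 3-methylphenyl for 4,5-dimethyl-1,3-thiazol-2-yl gives the series its first single-place step in this assay: a 3.0-fold higher number from compound 2 to compound 3 (0.48 log units; beyond the scatter). The two groups match in heavy-atom count and in having no net charge; they differ in a six-membered aromatic ring of carbon only against a five-membered aromatic ring with 2 hetero atoms and 2 hydrogen-bond acceptors. No measured property available here bears on what drives this step.

A single exchange does not separate the contribution of the ring hetero atoms from that of the two methyl groups. Also open, from the compounds shown here alone, is how a 1,3-thiazol-2-yl group without methyl groups, or a pyridinyl group, would read at this carbon.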